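The source may hold more compounds than are shown below. What is called first, only, known or untested is meant among the compounds shown, and "the series" means these compounds.

Compound 1 `COc1ccc2c(=O)c(/C=C/C(=O)Nc3ccccc3Cl)coc2c1`: 23000 nM
Compound 2 `COc1ccc2c(=O)c(/C=C/C(=O)Nc3ccc(Cl)cc3)coc2c1`: a limit only, > 100000 nM

In a functional assay (QGY7701 cells, Homo sapiens) for inhibition, read by MTT assay, with a stated time of 48 h (on this read-out lower numbers stand for stronger inhibition and higher numbers for weaker inhibition), compound 1 gives 23000 nM. For compound 2 the assay reports no number but only a limit, > 100000 nM. Compound 2 thus stands at the weaker end of the two values shown, and the step of an at least 4.3-fold higher number from compound 1 to compound 2 (0.63 log units; beyond the scatter) places it at least modestly below compound 1 in inhibition; its value sits at the assay limit, as noted in the limit of > 100000 nM in this assay, at which 1 of the 2 values shown sits.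

Compound 3, `CCOc1ccc(NC(=O)/C=C/c2coc3cc(OC)ccc3c2=O)cc1`, differs from compound 2 by ethoxy in place of chloro on an aromatic carbon. Going by the values given here, no measured step changes this group: the single step in hand, an at least 4.3-fold higher number from compound 1 to compound 2 (0.63 log units; beyond the scatter), concerns where a chloro sits, not its exchange for ethoxy, so it gives no direction for the new change. Compound 3 is therefore expected to remain near the limit at which compound 2 sits, with an estimate of 100000 nM and a range from 30000 nM to 300000 nM. The expected step of a number no higher from compound 2 to compound 3 (the limit leaves the size open) is accordingly none beyond the scatter.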

Compound 3, half-maximal inhibitory concentration: > 100000 nM
Compound 3: a limit, no number; the forecaster's own chance of this, stated with the estimate: 60%; the middle value lies on the limit itself.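

In this assay compound 3 gives only a limit, > 100000 nM, so placing ethoxy instead of chloro on this aromatic carbon, para to a large group, yields no number. With two limits, the step between compound 2 and compound 3 cannot be read, and neither compound can be ranked against the other. What can be read is an at least 4.3-fold higher number from compound 1 to compound 3 (0.63 log units; beyond the scatter), which gives a second compound falling short of compound 1, and the values now gather at one point: the limit of > 100000 nM in this assay, at which 2 of the 3 values shown sit.

The compounds shown leave open whether a different group on this aromatic carbon, such as an amine or a carboxylic acid, would give a number at all. Also open, on these data alone, is how far the true values of compound 2 and compound 3 lie from each other.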